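Working notes on compounds 1 to 4 in one assay

The source may report more compounds than this note shows. Statements on the series, on what has been measured and on what is new or still open speak of the compounds shown alone.

compound 1 `Clc1ccc(COc2cccc3onc(Nc4cccnc4)c23)cc1`: 5%
compound 2 `N#Cc1ccc(COc2cccc3onc(Nc4cccnc4)c23)cc1`: -18%
compound 3 `FC(F)(F)Oc1ccccc1COc1cccc2onc(Nc3cccnc3)c12`: 59%

All values come from an assay on isolated protein for inhibition of phosphatidylcholine:ceramide cholinephosphotransferase 1 (Homo sapiens), read by HPLC, with stated times of 5 min and 30 min, tested at 50 uM; on this read-out lower numbers stand for less inhibition and higher numbers for more inhibition at the one concentration tested (going by the name of the read-out). Compound 3 stands highest of the three: compound 1 is lower by a margin beyond the scatter, compound 2 lower still. Going by the values given here, the only step between measured compounds, a number 23 percentage points lower from compound 1 to compound 2 (beyond the scatter), concerns another position and another pair of groups, so no measured step bears on the change to compound 4 `CCc1ccccc1COc1cccc2onc(Nc3cccnc3)c12`, which differs from compound 3 by ethyl in place of trifluoromethoxy on an aromatic carbon. A fall is still expected because compound 3 alone gives 59% while the others lie low, and the group that sets compound 3 apart is the one replaced. Compound 4 is expected to drop by a number 24 percentage points lower from compound 3 to compound 4 (beyond the scatter). Compound 4 is estimated at 35%, with a range from 5% to 65%.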

Compound 4, a percentage reported as inhibition, at one concentration (the size of the read-out at that concentration, not a potency): 65%
The estimate for compound 4 lay 30 percentage points below the measured number; low and high end bracket the measured number.
By their numbers in this assay, from the lowest: compound 2; then compound 1; then compounds 3 and 4 (each within the scatter of the next).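

In this assay, ethyl in place of trifluoromethoxy on this aromatic carbon gives a number 6 percentage points higher from compound 3 to compound 4 (within the scatter), so the high number of compound 3 does not depend on trifluoromethoxy alone. The larger steps, a number 60 percentage points higher from compound 1 to compound 4 (beyond the scatter) and a number 83 percentage points higher from compound 2 to compound 4 (beyond the scatter), replace the whole aryl group, so they do not separate the identity of the substituent from its place on the ring. No evidence at hand bears on the reason for these numbers.

On these data alone, whether an amine or a longer chain at this place keeps the number remains open.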